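A few compounds are considered here, and "the series" means these few. Any claim that something is new, unique, unknown or untested is made for them only; others in the source may bear on it.

Measured so far:
- compound 1, `CC(C)(C)[C@@H](O)C(=O)N1[C@@H]2C[C@@H]2C[C@H]1C(=O)NCc1cc(Cl)ccc1-n1cnnn1`: 1100 nM
- compound 2, `O=C(NCc1cc(Cl)ccc1-n1cnnn1)[C@@H]1CCON1C(=O)[C@H](O)c1ccccc1`: 1500 nM
- compound 3, `CC(C)(C)[C@@H](O)C(=O)N1N=CC[C@H]1C(=O)NCc1cc(Cl)ccc1-n1cnnn1`: 1400 nM

All three were run in a functional assay on a cell-free system (plasma, Homo sapiens), with a stated time of 3 min; a lower number here means a stronger inhibitor, a higher number a weaker inhibitor. The three numbers sit close together. Compound 1 has the lowest of them, but the gap to compound 3 and the gap to compound 2 both lie within the usual scatter, so none of the three is set apart from the others.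

Compound 4, `CCCC[C@@H](O)C(=O)N1[C@@H]2C[C@@H]2C[C@H]1C(=O)NCc1cc(Cl)ccc1-n1cnnn1`, has not yet been measured. It differs from compound 1 by butyl in place of tert-butyl on a saturated chain carbon bound to a carbonyl carbon and an oxygen on a saturated carbon; the two share the same atoms, joined differently. For the measured compounds named here, no pair among the measured compounds shows this kind of change, so nothing here tells how large its effect will be or in which direction. With no comparison of this kind available, the expectation for the step from compound 1 to compound 4 is a small shift toward a higher number, estimated at a 1.8-fold higher number from compound 1 to compound 4 (0.26 log units; within the scatter), which may or may not clear the scatter. Compound 4 is accordingly expected to give about 2000 nM in this assay, within a range of 800 nM to 5000 nM.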

Compound 4, half-maximal inhibitory concentration: 870 nM
Beside the measured number, compound 4's estimate is 2.3-fold (0.36 log units) above it; measured number inside the range.
By their numbers in this assay, from the lowest: compounds 4, 1, 3 and 2 (each within the scatter of the next).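

In this assay, for the compounds shown here, butyl in place of tert-butyl on a saturated chain carbon bound to a carbonyl carbon and an oxygen on a saturated carbon gives a 1.3-fold lower number from compound 1 to compound 4 (0.10 log units; within the scatter), the first step that changes this position alone. On the core of compound 1, tert-butyl is therefore not required at this place: butyl, with the same atoms joined differently, stays within the scatter of it. Nothing at hand gives a reason for this outcome.

As far as these compounds go, whether a shorter chain such as ethyl, a longer chain such as hexyl, or a chain carrying an amine or a carboxylic acid would move the number beyond the scatter remains open. Also open, from the compounds shown here alone, is whether the same change gives a similar step on the core of compound 3, which carries tert-butyl too.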